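Methyl for trifluoromethyl on the core of compound 3

The compounds below may be only part of what the source reports. "The series", "measured", "known", "first", "only" and "open" are said of these compounds alone.

The series shares the core of compound 1 `Nc1nc2ccccn2c1-c1ccc(O)cc1`. In an assay on isolated protein for inhibition of ubiquitin carboxyl-terminal hydrolase 1 (Homo sapiens) (a higher number here means a weaker inhibitor, a lower number a stronger inhibitor), compound 1 gives only a limit of the assay, > 100000 nM. Compound 2 `CN(C)c1nc2ccccn2c1-c1ccc(O)cc1` carries a dimethylamino in place of the amino on an aromatic carbon. In this assay compound 2 likewise gives only a limit, > 100000 nM. Compound 3 `Nc1nc2c(C(F)(F)F)cccn2c1-c1ccc(O)cc1` carries a trifluoromethyl in place of hydrogen on an aromatic carbon. In this assay compound 3 also gives only a limit, > 100000 nM. Compound 3 therefore stands nowhere readable: the limit of > 100000 nM in this assay, at which 3 of the 3 values shown sit, so none of the three can be ranked against another. The step from compound 1 to compound 2 is a step that the two limits leave unreadable from compound 1 to compound 2, and the step from compound 1 to compound 3 is a step that the two limits leave unreadable from compound 1 to compound 3; neither yields a size.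

Compound 4 `Cc1cccn2c(-c3ccc(O)cc3)c(N)nc12` differs from compound 3 by methyl in place of trifluoromethyl on an aromatic carbon. Within the data shown here, the only measured step touching this position, a step that the two limits leave unreadable from compound 1 to compound 3, is unreadable, so no size or direction can be drawn for the change in this assay. Because every value shown sits at the limit of > 100000 nM in this assay, at which 3 of the 3 values shown sit, compound 4 is expected to remain at that limit, with an expected step of a number no higher from compound 3 to compound 4 (the limit leaves the size open) that cannot be told from none. The estimate for compound 4 in this assay is 100000 nM, expected within 30000 nM to 300000 nM.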

Compound 4, half-maximal inhibitory concentration: > 100000 nM
Compound 4: a limit, no number; the forecaster's own chance of this, stated with the estimate: 85%; the middle value sits exactly at the limit.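

In this assay compound 4 gives > 100000 nM as a limit of the assay, and the steps to it from compound 1 and compound 3 cannot be read: the limit of > 100000 nM in this assay, at which 4 of the 4 values shown sit.

The compounds shown leave open whether any change on the shared core gives a readable value.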